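A few compounds are considered here, and "the series" means these few. Any claim that something is new, unique, unknown or untested is made for them only; others in the source may bear on it.

Measured so far in a functional assay on SK-OV-3 cells (Homo sapiens) for cytotoxicity, read by sulforhodamine B assay, with a stated time of 48 h; a lower number here means a stronger inhibitor of growth, a higher number a weaker inhibitor of growth:
Compound 1 `COc1cc(C(=O)c2ccc(OC)c(O)c2OC)cc(OC)c1O` gives 912 nM
Compound 2 `COc1cc(C(=O)c2ccc3c(c2)oc(=O)n3S(C)(=O)=O)cc(OC)c1OC` gives 2840 nM

Of these two, compound 1 has the lower number and is therefore the stronger inhibitor of growth. Its gap to compound 2 lies beyond the usual scatter of repeated measurements.

Compound 3 `COc1ccc(C(=O)c2cc(OC)c(OC)c(OC)c2)c(OC)c1O` has not yet been measured. It differs from compound 1 in one place: methyl in place of hydrogen on an oxygen on an aromatic ring, or hydroxy to methoxy.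

Among the measured compounds shown here, no measured pair shows this change, so the data offer no direct size for it. For the measured compounds named here, only one small group is swapped, so a modest step is expected in this assay, more likely toward a lower number, although a move the other way cannot be ruled out. The only anchor for this expectation is compound 1 with 912 nM, so the range has to stay wide. The expected move is a 2.3-fold lower number from compound 1 to compound 3 (0.36 log units; beyond the scatter) as an estimate. For compound 3 the estimated value is 400 nM (expected range 70 nM to 2300 nM).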

Compound 3, concentration for 50% growth inhibition: 89.6 nM
Estimate against measurement, compound 3: 4.5-fold (0.65 log units) above; the measured number falls inside the stated range.
By their numbers in this assay, from the lowest: compound 3; then compound 1; then compound 2.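

In this assay, methyl in place of hydrogen on this oxygen on an aromatic ring, or hydroxy to methoxy, gives a 10-fold lower number from compound 1 to compound 3 (1.01 log units; beyond the scatter), a large step for the addition of a single carbon. Compound 1 carries a second hydroxy group, which stays in place in compound 3, so this step belongs to one oxygen alone, and a hydrogen on that oxygen is clearly not needed for compound 3 to reach 89.6 nM in this measurement. Nothing at hand explains why the step is so large. From the compounds shown here alone, whether the methyl group itself matters, or whether simply losing the hydrogen is enough, stays open, since a longer chain such as ethyl on this oxygen, or an amine or a fluorine in place of the hydroxy, would be needed to tell these apart. The remaining hydroxy group of compound 3 is also untested, so a single step cannot say whether turning it into methoxy would lower the number further, leave it unchanged, or raise it.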